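Propargyl in place of a branched ester on the sulfur

The source may report more compounds than this note shows. Statements on the series, on what has been measured and on what is new or still open speak of the compounds shown alone.

Compounds and their values:
Compound 1 `CCOC(=O)CSc1nc2cc(-n3nc(C(C)(C)C)sc3=O)c(F)cc2s1` gives 340 nM in an assay on isolated protein for inhibition of protoporphyrinogen oxidase (Homo sapiens), read by capillary electrophoresis; a lower number here means a stronger inhibitor, a higher number a weaker inhibitor.
Compound 2 `CCOC(=O)CCSc1nc2cc(-n3nc(C(C)(C)C)sc3=O)c(F)cc2s1` gives 9260 nM in this assay.
Compound 3 `CCOC(=O)C(C)(C)Sc1nc2cc(-n3nc(C(C)(C)C)sc3=O)c(Cl)cc2s1` gives 34400 nM in this assay.

Compound 3 has the highest number of the three, so it is the weakest inhibitor shown. Compound 2 lies nearest to it, and compound 1 is furthest away with a far lower number. For the measured compounds named here, the only step between compounds that differ in a single place is a 27-fold higher number from compound 1 to compound 2 (1.44 log units; beyond the scatter), and it shows that lengthening the chain on the sulfur by one carbon raised the number sharply. Compound 3 carries a still bulkier group on that sulfur, and its number is the highest of all.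

Compound 4 `C#CCSc1nc2cc(-n3nc(C(C)(C)C)sc3=O)c(Cl)cc2s1` differs from compound 3 by propargyl in place of 1-(ethoxycarbonyl)-1-methylethyl on a sulfur. Nothing measured here contains a propargyl group, so the step cannot be read directly from a shown pair. What the shown compounds do say is that the smallest group on the sulfur, in compound 1, went with the lowest number, and that each larger group went with a higher one. On that basis compound 4 is expected to give a lower number than compound 3, by about a 23-fold lower number from compound 3 to compound 4 (1.36 log units; beyond the scatter), with wide uncertainty. The estimate for compound 4 in this assay is 1500 nM, within a range from 200 nM to 12000 nM.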

Compound 4, inhibition constant: 21400 nM
Estimate against measurement, compound 4: 14-fold (1.15 log units) below; the measured number lies above the stated range.
By their numbers in this assay, from the lowest: compound 1; then compound 2; then compounds 4 and 3 (each within the scatter of the next).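

In this assay, compound 3 and compound 4 stand level (a 1.6-fold lower number from compound 3 to compound 4 (0.21 log units; within the scatter)), even though the change replaces 1-(ethoxycarbonyl)-1-methylethyl, with its 8 heavy atoms and 2 hydrogen-bond acceptors, by propargyl, with 3 carbons and no hydrogen-bond acceptors. For the compounds shown here, this is the first pair in which a much smaller group on this sulfur does not come with a number beyond the scatter of the larger group's, so compound 4 goes against the link between size and number suggested by compounds 1, 2 and 3, and neither the ester nor its bulk separates these two compounds. Nothing shown here offers a measured explanation for this result.

On these data alone, compounds 1 and 2 carry fluorine where compounds 3 and 4 carry chlorine and also differ from them on the sulfur, so steps between these two sets cannot be read, and the share of the halogen in their gap stays unknown. Also open, as far as these compounds go, is how this position would respond to a plain methyl, a longer chain ending in a carboxylic acid, or an amine on the sulfur, or to (ethoxycarbonyl)methyl on the sulfur with chlorine in the core.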